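A few compounds are considered here, and "the series" means these few. Any claim that something is new, unique, unknown or untested is made for them only; others in the source may bear on it.

Compound 1 `Fc1ccc2nc(NCCCCN3CCN(c4cccc(Cl)c4Cl)CC3)nc(NCc3ccco3)c2c1`: in a functional assay on MCF7 cells (Homo sapiens) for cytotoxicity, read by MTT assay, with a stated time of 2 days (on this read-out lower numbers stand for stronger inhibition and higher numbers for weaker inhibition), compound 1 gives "not determined" (no result reported), no result having been obtained.
Compound 2 `Cc1cccc(N2CCN(CCCCNc3nc(NCc4ccco4)c4cc(F)ccc4n3)CC2)c1C`: in this assay compound 2 gives 3130 nM.
Compound 3 `Clc1cccc(N2CCN(CCCCNc3nc(NCc4ccco4)c4ccccc4n3)CC2)c1Cl`: in this assay compound 3 gives 2970 nM.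

Within the data shown here, only two numbers exist here, and compound 3 and compound 2 lie within the usual scatter of each other, so neither can be called the more potent. Compound 4 `Cc1cccc(N2CCN(CCCCNc3nc(NCc4ccco4)c4ccccc4n3)CC2)c1C` has not yet been measured. It differs from compound 3 in one place: 2,3-dimethylphenyl in place of 2,3-dichlorophenyl on an amine nitrogen in a ring. Among the measured compounds shown here, no pair of measured compounds shows this change on its own, so its size cannot be read from a single step. Still, compound 2 already carries the 2,3-dimethylphenyl on the same ring nitrogen and gives 3130 nM, close to compound 3. In this assay the expected step is a 1.1-fold higher number from compound 3 to compound 4 (0.03 log units; within the scatter), staying within the scatter. Compound 4 is estimated at 3200 nM, with a range from 1500 nM to 7000 nM.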

Compound 4, half-maximal inhibitory concentration: 3140 nM
For compound 4 the middle estimate is 1.0-fold (0.01 log units) above the measured one; the range from low to high includes it.
By their numbers in this assay, from the lowest: compounds 3, 2 and 4 (each within the scatter of the next).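

The change from 2,3-dichlorophenyl to 2,3-dimethylphenyl on the ring nitrogen can now be read on its own: in this assay it is a 1.1-fold higher number from compound 3 to compound 4 (0.02 log units; within the scatter), so the two groups cannot be told apart here. Hydrogen in place of fluoro on the aromatic carbon, a second single change, is a 1.0-fold higher number from compound 2 to compound 4 (0.00 log units; within the scatter), and it too cannot be told apart from no difference. Nothing available explains either result.

Going by these compounds, whether an amine or a carboxylic acid in place of these aryl groups would shift the number remains open. So does the effect of a longer chain.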